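This account rests on a few compounds, and the source may have more. Where it says the series, first, only, none or still open, it means among the compounds named here.

Three closely related compounds have so far been measured in a physicochemical assay for lipophilicity, at pH 7.4 (on this read-out higher numbers stand for higher lipophilicity and lower numbers for lower lipophilicity), and their numbers sit close together. Compound 1 (`CCc1ccc(N(Cc2ccccc2)S(=O)(=O)c2ccc3c(c2)C(=O)CC(C2CCOCC2)O3)cc1`) gives 4.84 and compound 2 (`CC(C)CN(c1ccc(C(C)(C)C)cc1)S(=O)(=O)c1ccc2c(c1)C(=O)CC(C1CCOCC1)O2`) gives 4.97 while compound 3 (`CCc1ccc(N(CC(C)C)S(=O)(=O)c2ccc3c(c2)C(=O)CC(C(C)C2CCOCC2)O3)cc1`) gives 4.93 in the same measurement. Compound 2 lies within the scatter of both of the others, so the three cannot be ranked on these numbers. Among the measured compounds shown here, no two of them differ in a single place, and the data therefore offer no measured step to lean on.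

Attention now turns to compound 4 (`CC(C)CN(c1ccc(N(C)C)cc1)S(=O)(=O)c1ccc2c(c1)C(=O)CC(C1CCOCC1)O2`), which has not yet been measured. It differs from compound 2 in one place: dimethylamino stands in place of tert-butyl on an aromatic carbon, para to a large group (dimethylamino in place of tert-butyl on an aromatic carbon). In this exchange a nitrogen enters and a hydrogen-bond acceptor comes with it, where the departing group has none. On that structural change alone, and starting from the value of compound 2 (4.97), a fall in the number is expected. The estimated step is downward and beyond the scatter (a number 0.77 log units lower from compound 2 to compound 4 (beyond the scatter)). Compound 4 is expected to read 4.2 in this assay (estimated range from 3.6 to 4.7).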

Compound 4, distribution coefficient: 3.6
The estimate for compound 4 lay 0.60 log units above the measured number; low and high end bracket the measured number.
By their numbers in this assay, from the lowest: compound 4; then compounds 1, 3 and 2 (each within the scatter of the next).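

In this assay, dimethylamino in place of tert-butyl on an aromatic carbon, para to a large group, gives a number 1.37 log units lower from compound 2 to compound 4 (beyond the scatter). The earlier compounds shown here offered no step and their numbers lay within the scatter of one another, whereas this pair shows that a single exchange at this position, bringing in a nitrogen and a hydrogen-bond acceptor, can move the number well beyond the scatter. No measurement here bears on what lies behind the size of this step.

The compounds shown leave open how much of the step goes with the nitrogen itself and how much with the departure of tert-butyl, a question that a compound with isopropyl, a group of carbon only, at this same place would help to settle. They also leave open whether a methoxy group or a plain amino group at this place would bring the number down as far as dimethylamino does, and so whether the step belongs to dimethylamino alone or extends to other groups carrying a nitrogen or an oxygen.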